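The source may report more compounds than this note shows. Statements on the series, on what has been measured and on what is new or still open speak of the compounds shown alone.

Measured compounds:
compound 1 `C=CCn1ncc2cnc(Cc3ccccc3)n2c1=O` – > 48000 nM
compound 2 `C=CCn1ncc2cnc(COC)n2c1=O` – > 48000 nM
compound 3 `C=CCn1ncc2c(Br)nc(Cc3ccccc3)n2c1=O` – > 48000 nM

In a functional assay for inhibition, with Homo sapiens as the target (on this read-out higher numbers stand for weaker inhibition and lower numbers for stronger inhibition), compound 1 gives > 48000 nM, a limit of the assay and not a number. The same holds for compound 2 and compound 3, so the steps a step that the two limits leave unreadable from compound 1 to compound 2 and a step that the two limits leave unreadable from compound 1 to compound 3 cannot be read, since (the limit of > 48000 nM in this assay, at which 3 of the 3 values shown sit). Compound 4 `Cn1ncc2cnc(Cc3ccccc3)n2c1=O` differs from compound 1 by hydrogen in place of vinyl on a saturated chain carbon bound to an aromatic nitrogen. Among the compounds with values here, no measured step touches this place, and the two measured steps give no readable size, so the expected step that the limit leaves unreadable from compound 1 to compound 4 rests only on the shared standing of the series at the limit. Compound 4 is therefore expected to give 60000 nM in this assay, within 20000 nM to 200000 nM, most likely reported again as a limit.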

Compound 4, half-maximal inhibitory concentration: > 48000 nM
Compound 4: only a limit was reported; the forecaster's own chance of this, stated with the estimate: 85%; the middle value is on the limit's open side.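

Compound 4 gives > 48000 nM, a limit and not a number. Its step from compound 1, also a limit, cannot be read: the limit of > 48000 nM in this assay, at which 4 of the 4 values shown sit.

The compounds shown leave open whether any change to the shared core gives a measurable value in this assay.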